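A few compounds are considered here, and "the series" means these few. Any claim that something is new, unique, unknown or untested is made for them only; others in the source may bear on it.

Compound 1 `COc1ccc(-c2cnc(Nc3ccc(C#N)cc3)nc2Oc2c(C)cc(C#N)cc2C)cc1`: > 279000 nM
Compound 2 `Cc1ccc(-c2cnc(Nc3ccc(C#N)cc3)nc2Oc2c(C)cc(C#N)cc2C)cc1`: 26100 nM

In an ADME assay on MT4 cells (Homo sapiens) for cytotoxicity, read by MTT assay, with a stated time of 5 days (on this read-out lower numbers stand for higher toxicity in this test and higher numbers for lower toxicity in this test), compound 1 gives a limit, > 279000 nM, not a number. Compound 2 gives 26100 nM in this assay, and the measured step is an at least 10-fold lower number from compound 1 to compound 2 (1.02 log units; beyond the scatter). Compound 3 `Cc1cc(C#N)cc(C)c1Oc1nc(Nc2ccc(C#N)cc2)ncc1-c1ccoc1` differs from compound 1 by furan-3-yl in place of 4-methoxyphenyl on an aromatic carbon. Going by the values given here, the only measured step exchanges methoxy for methyl and does not cover a change to furan-3-yl, so it offers no direct guide for this assay. A step of an at least 1.8-fold lower number from compound 1 to compound 3 (0.26 log units; that floor lies within the scatter) is expected, with a fair chance that the result is again a limit. Compound 3 is estimated at 150000 nM, between 25000 nM and 400000 nM.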

Compound 3, half-maximal cytotoxic concentration: 4980 nM
For compound 3 the middle estimate is 30-fold (1.48 log units) above the measured one; the measured number lies below the stated range.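

In this assay, furan-3-yl at this position gives an at least 56-fold lower number from compound 1 to compound 3 (1.74 log units; beyond the scatter), and also a 5.2-fold lower number from compound 2 to compound 3 (0.72 log units; beyond the scatter). Replacing the whole six-membered ring, not only the group on it, therefore shifts toxicity in this test, and compound 3 has the lowest number of the three, beyond the scatter from both others. Compound 1 gives only a limit, so the first step has a floor and no exact size: the limit of > 279000 nM in this assay, at which 1 of the 3 values shown sits.

On these data alone, it remains open whether ring size or the ring oxygen drives the shift. A thiophene or pyridine ring on this carbon could help separate the two.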